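The source may report more compounds than this note shows. Statements on the series, on what has been measured and on what is new or still open speak of the compounds shown alone.

Compounds measured so far:
compound 1 `CC[C@H](C)[C@H](N)CN(C(=O)[C@@H]1C[C@H]1c1cccs1)c1ccc(-c2ccccc2)cc1` — 360 nM
compound 2 `Cc1ccc(-c2ccc(N(C[C@@H](N)CC(C)C)C(=O)[C@@H]3C[C@H]3c3ccccc3)cc2)cc1` — 360 nM

In a functional assay for agonist activity at G protein-coupled receptor 88 (Homo sapiens), read by HTRF and cAMP accumulation (a higher number here means that more compound is needed for the effect, a lower number that less compound is needed), compound 2 gives 360 nM, level with compound 1 at the digits shown, within the scatter. Compound 3 `CC(C)C[C@H](N)CN(C(=O)[C@@H]1C[C@H]1c1ccccc1)c1ccc(-c2ccccc2F)cc1` carries the change 2-fluorophenyl in place of 4-methylphenyl on an aromatic carbon, para to a large group. For the measured compounds named here, no step between measured compounds bears on this change, so the expected step from compound 2 to compound 3 in this assay is small, within the scatter, with no clear direction: a 1.1-fold higher number from compound 2 to compound 3 (0.05 log units; within the scatter). Compound 3 is estimated at 400 nM, within 130 nM to 1200 nM.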

Compound 3, half-maximal effective concentration: 1600 nM
Beside the measured number, compound 3's estimate is 4.0-fold (0.60 log units) below it; the whole stated range lies below it.
By their numbers in this assay, from the lowest: compounds 1 and 2 (each within the scatter of the next); then compound 3.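

In this assay, 2-fluorophenyl in place of 4-methylphenyl on this aromatic carbon, para to a large group, gives a 4.4-fold higher number from compound 2 to compound 3 (0.65 log units; beyond the scatter). This position therefore responds to the exchange, although the heavy-atom count, hydrogen-bond donors, hydrogen-bond acceptors and net charge of the group stay the same. No measurement at hand accounts for the shift.

This single step cannot separate losing the 4-methyl group from gaining the 2-fluoro group. 4-Fluorophenyl and 2-methylphenyl at this place on the compound 2 framework would separate the two, and a 4-methoxyphenyl group would test a larger substituent there.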